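Methoxy on the benzylic ring of a sulfone series

This account rests on a few compounds, and the source may have more. Where it says the series, first, only, none or still open, it means among the compounds named here.

Measured compounds in a functional assay on CHO.K1 cells for antagonist activity at prostaglandin D2 receptor 2 (Homo sapiens), read by GTPgammaS binding, with a stated time of 1 h; on this read-out higher numbers stand for weaker inhibition and lower numbers for stronger inhibition:
compound 1, `Cc1c(Cc2cc(Br)ccc2S(=O)(=O)c2ccccc2)c2c(n1CC(=O)O)CCNC2=O`, 3.9 nM
compound 2, `CNC(=O)c1cccc(S(=O)(=O)c2ccccc2Cc2c3c(n(CC(=O)O)c2C)CCNC3=O)c1`, 240 nM
compound 3, `Cc1c(Cc2ccccc2S(=O)(=O)c2ccc(F)cc2)c2c(n1CC(=O)O)CC(C)(C)NC2=O`, 5 nM

Compound 3 sits second highest of the three numbers in this assay. Its nearest neighbour is compound 1, whose value is within the scatter of that of compound 3, so the two cannot be ranked against each other. Compound 2, which carries a methylaminocarbonyl group on the phenylsulfonyl ring, gives a number far higher than compound 3, well beyond the scatter, and is the weakest of the three.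

Compound 4 is `COc1ccc(S(=O)(=O)c2ccc(F)cc2)c(Cc2c3c(n(CC(=O)O)c2C)CC(C)(C)NC3=O)c1`. It differs from compound 3 by a single change: methoxy in place of hydrogen on an aromatic carbon. The new group sits on an aromatic carbon of a six-membered aromatic ring of carbon only, meta to a large group and para to a (4-fluorophenyl)sulfonyl group. Going by the values given here, no pair of measured compounds shows this same change, so no measured step guides the expectation. Compound 1 and compound 3, which both keep the unsubstituted or halogen-bearing pattern on that ring, give numbers within scatter of each other, so a small addition here is expected to move the number little. The step from compound 3 to compound 4 is therefore estimated to be none beyond the scatter, a 1.2-fold higher number from compound 3 to compound 4 (0.08 log units; within the scatter). Compound 4 is expected to give 6 nM, in a range from 2 nM to 20 nM.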

Compound 4, half-maximal inhibitory concentration: 5 nM
Compound 4: middle estimate off by 1.2-fold (0.08 log units), on the high side; the measured number falls inside the stated range.
By their numbers in this assay, from the lowest: compounds 1, 3 and 4 (each within the scatter of the next); then compound 2.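

Read in this assay the replacement of hydrogen by methoxy gives no change at the digits printed from compound 3 to compound 4 (within the scatter) and is the first change in this set that can be read at a single place. Going by these compounds alone, it shows that this aromatic carbon, meta to a large group and para to a (4-fluorophenyl)sulfonyl group, can carry methoxy, with its 2 heavy atoms and 1 hydrogen-bond acceptor, without a shift beyond the scatter, something the earlier compounds could not show since each of them differs from the others in more than one place. Nothing measured here accounts for this outcome, so the result stands as an observation about the number alone.

From the compounds shown here alone, what remains open is whether this position accepts groups of another kind, such as an amine, a carboxylic acid or a longer chain like butoxy, or whether a smaller hydroxy or a fluorine would read the same way. Within the data shown here, it is equally open whether methoxy at this carbon would leave the number unmoved on a compound with a different sulfonyl ring, such as the one bearing the methylaminocarbonyl group in compound 2.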